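Methoxy to Bromo on a Shared Core: Expecting Compound 4

The source may hold more compounds than are shown below. What is called first, only, known or untested is meant among the compounds shown, and "the series" means these compounds.

Compound 1 `COc1ccc(-c2cn(C[C@H]3c4c(ccc(OS(=O)(=O)c5ccc(C)cc5)c4C)[C@@H]4CC[C@@]5(C)C[C@]43CC5=O)nn2)cc1`: > 20000 nM
Compound 2 `Cc1ccc(S(=O)(=O)Oc2ccc3c(c2C)[C@H](Cn2cc(-c4ccc(Br)cc4)nn2)[C@@]24CC(=O)[C@@](C)(CC[C@@H]32)C4)cc1`: > 20000 nM
Compound 3 `C=C1C(=O)[C@]23C[C@@]1(O)CC[C@H]2c1ccc(O)c(C)c1[C@@H]3Cn1cc(-c2ccc(OC)cc2)nn1`: 1710 nM

In a functional assay on MCF7 cells (Homo sapiens) for cytotoxicity, read by MTT assay, with a stated time of 4 days (on this read-out lower numbers stand for stronger inhibition and higher numbers for weaker inhibition), compound 1 returns only a limit of the assay, > 20000 nM. Compound 2 also returns only a limit, > 20000 nM. Compound 3 gives a measured number, 1710 nM. The difference between the cores of compound 1 and compound 3 is not broken down here. From compound 1 to compound 2 the change is bromo in place of methoxy on an aromatic carbon, and its step is a step that the two limits leave unreadable from compound 1 to compound 2; the size cannot be read because of the limit of > 20000 nM in this assay, at which 2 of the 3 values shown sit. Compound 4 `C=C1C(=O)[C@]23C[C@@]1(O)CC[C@H]2c1ccc(O)c(C)c1[C@@H]3Cn1cc(-c2ccc(Br)cc2)nn1` carries the same change relative to compound 3, namely (bromo in place of methoxy on an aromatic carbon). Within the data shown here, with the only earlier instance of this change unreadable in a step that the two limits leave unreadable from compound 1 to compound 2, the step is expected to be modest, a 1.1-fold higher number from compound 3 to compound 4 (0.02 log units; within the scatter). Compound 4 is therefore estimated at 1800 nM, expected to fall between 700 nM and 5000 nM.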

Compound 4, half-maximal inhibitory concentration: 270 nM
Estimate against measurement, compound 4: 6.7-fold (0.82 log units) above, outside the stated range (below it).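

On the core of compound 3, this assay shows that bromo in place of methoxy gives a 6.3-fold lower number from compound 3 to compound 4 (0.80 log units; beyond the scatter). The same change on the other core cannot be read, because compound 1 and compound 2 both return only a limit of the assay: the limit of > 20000 nM in this assay, at which 2 of the 4 values shown sit. The series therefore offers one readable instance of this change, on one core, and does not show whether the step carries from one core to another.

From the compounds shown here alone, it remains open how an amine or a carboxylic acid in the same place would compare with methoxy and bromo. Going by these compounds, it also remains open whether a similar step would appear on another core with values that are not limits.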